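Branching the Amide Substituent on a Shared Core

The source may hold more compounds than are shown below. What is called first, only, known or untested is meant among the compounds shown, and "the series" means these compounds.

Among the compounds with values here, compound 2 `Cc1nn(-c2ncnc3nc[nH]c23)c2c1C(NC(=O)c1ccccc1)CC(=O)N2` gives the lower of the two numbers recorded in a functional assay on HEK293 cells for agonist activity at G-protein coupled receptor 39 (Homo sapiens), read by scintillation proximity assay and inositol phosphate accumulation, with a stated time of 75 min (a lower number here means that less compound is needed, a higher number that more compound is needed for the effect), namely 158 nM; its only neighbour, compound 1 `Cc1nn(-c2ncnc3nc[nH]c23)c2c1C(NC(=O)Cc1cccs1)CC(=O)N2`, gives 244 nM, and the step of a 1.5-fold lower number from compound 1 to compound 2 (0.19 log units; within the scatter) lies within the scatter. Compound 3 `CCC(C(=O)NC1CC(=O)Nc2c1c(C)nn2-c1ncnc2nc[nH]c12)c1ccccc1` carries 1-phenylpropyl in place of phenyl on a carbonyl carbon. Within the data shown here, only one measured step, the exchange of the group on the same carbonyl carbon, bears on this change, and it was small. The account therefore expects for compound 3 in this assay a step of a 1.3-fold higher number from compound 2 to compound 3 (0.10 log units; within the scatter) that stays within the scatter. Compound 3 is thus estimated at 200 nM, with a range from 60 nM to 700 nM.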

Compound 3, half-maximal effective concentration: 79 nM
Beside the measured number, compound 3's estimate is 2.5-fold (0.40 log units) above it, and the stated range covers the measured number.
By their numbers in this assay, from the lowest: compounds 3, 2 and 1 (each within the scatter of the next, the first and the last beyond it).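

In this assay, putting a branched 1-phenylpropyl group on the carbonyl carbon in place of phenyl, with its larger count of carbon atoms, produces a step that stays within the scatter (a 2.0-fold lower number from compound 2 to compound 3 (0.30 log units; within the scatter)). Set against the (thiophen-2-yl)methyl group, however, the same group produces the first step in this series beyond the scatter, though only a modest one (a 3.1-fold lower number from compound 1 to compound 3 (0.49 log units; beyond the scatter)). On these data alone, how a 1-phenylethyl or a cyclohexyl group would read on the same carbonyl carbon remains open. Nothing given here accounts for either step.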